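A methoxy for a methyl in an antiproliferative series

This account rests on a few compounds, and the source may have more. Where it says the series, first, only, none or still open, it means among the compounds named here.

In a functional assay on MCF7 cells (Homo sapiens) for antiproliferative activity, read by MTT assay, with a stated time of 24 h (a higher number here means a weaker inhibitor, a lower number a stronger inhibitor), compound 1 (`CNC(=O)c1ccccc1Oc1nc(Nc2ccc(Br)cc2)ncc1Br`) gives > 50000 nM as its result, and that figure is a limit of the assay rather than a number. Within the data shown here, compound 2 (`CNC(=O)c1ccccc1Oc1nc(Nc2cccc(C)c2)ncc1Br`) gives 16600 nM in this assay and so holds the only true number so far. Among the measured compounds shown here, the single measured step of an at least 3.0-fold lower number from compound 1 to compound 2 (0.47 log units; beyond the scatter) lies beyond the scatter, but its size rests on a limit and it exchanged a whole aromatic group on the nitrogen, not a small substituent. Compound 3 (`CNC(=O)c1ccccc1Oc1nc(Nc2cccc(OC)c2)ncc1Br`) has methoxy in place of methyl on an aromatic carbon, meta to a large group methoxy in place of methyl on an aromatic carbon and is otherwise the same as compound 2. For the measured compounds named here, no measured step tests this exchange directly. Going by the values given here, with compound 2 at 16600 nM as the anchor and the step of an at least 3.0-fold lower number from compound 1 to compound 2 (0.47 log units; beyond the scatter) as the only guide to sensitivity, a small change with no firm direction is expected. The estimated step of a 1.1-fold lower number from compound 2 to compound 3 (0.04 log units; within the scatter) is expected to stay within the scatter. For compound 3 the expected value is 15000 nM with an estimated range from 6000 nM to 40000 nM as its span.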

Compound 3, half-maximal inhibitory concentration: 18200 nM
Compound 3: middle estimate off by 1.2-fold (0.08 log units), on the low side; the measured number falls inside the stated range.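

In this assay, methoxy in place of methyl on an aromatic carbon, meta to a large group, gives a 1.1-fold higher number from compound 2 to compound 3 (0.04 log units; within the scatter), so compound 2 and compound 3 cannot be told apart even though the exchange adds one oxygen and one hydrogen-bond acceptor. With 3-methoxyphenyl in place of 4-bromophenyl on the nitrogen, the result is an at least 2.7-fold lower number from compound 1 to compound 3 (0.43 log units; beyond the scatter), a second step in the same direction as an at least 3.0-fold lower number from compound 1 to compound 2 (0.47 log units; beyond the scatter), which shows that the lower number does not depend on methyl alone. Compound 1 holds a limit of the assay rather than a number, so the true size of both of these steps remains unknown: the limit of > 50000 nM in this assay, at which 1 of the 3 values shown sits.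

As far as these compounds go, whether a group other than methyl or methoxy at this position, such as an amine, a carboxylic acid or a longer chain, would shift the number beyond the scatter remains open. It is also open whether the gap to compound 1 follows from the bromine itself or from where the substituent sits on the ring; the steps shown change both at once.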